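This account rests on a few compounds, and the source may have more. Where it says the series, first, only, none or still open, it means among the compounds named here.

In a functional assay on HepG2 cells (Homo sapiens) for antiproliferative activity, read by MTT assay (a lower number here means a stronger inhibitor, a higher number a weaker inhibitor), compound 1 `O=C1C(=O)C2C(N=C3N=NNN3C23C(=O)Nc2c(Cl)cccc23)c2ccccc21` gives 3030 nM. For the measured compounds named here, the only other measured member, compound 2 `O=C1C(=O)C2C(N=C3N=NNN3C23C(=O)Nc2ccc(F)cc23)c2ccccc21`, gives 2860 nM, and the two values lie within the scatter of each other. Compound 3 `O=C1C(=O)C2C(N=C3N=NNN3C23C(=O)Nc2c(C(F)(F)F)cccc23)c2ccccc21` is still unmeasured. It carries trifluoromethyl in place of chloro on an aromatic carbon, ortho to a fused ring: trifluoromethyl in place of chloro on an aromatic carbon. Going by the values given here, no measured step covers this change, so no shift beyond the scatter is expected in this assay, and neither direction is favoured. The expected step is a 1.0-fold lower number from compound 1 to compound 3 (0.00 log units; within the scatter). For compound 3 the estimated value is 3000 nM, with an expected range of 1200 nM to 7500 nM.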

Compound 3, half-maximal inhibitory concentration: 7900 nM
The estimate for compound 3 lay 2.6-fold (0.42 log units) below the measured number; the whole stated range lies below it.
By their numbers in this assay, from the lowest: compounds 2 and 1 (each within the scatter of the next); then compound 3.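

In this assay, for the compounds shown here, trifluoromethyl in place of chloro on this aromatic carbon, ortho to a fused ring, gives a 2.6-fold higher number from compound 1 to compound 3 (0.42 log units; beyond the scatter) and so marks the first step beyond the scatter. This position therefore responds to the choice of substituent, and of these two groups chloro gives the lower number. No measurement available here accounts for the step. Still open, from the compounds shown here alone, is whether a methyl, a methoxy or an amine on this carbon would track chloro or trifluoromethyl. Also open, going by these compounds, is whether any group here would give a number lower than chloro does.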